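A few compounds are considered here, and "the series" means these few. Any claim that something is new, unique, unknown or untested is made for them only; others in the source may bear on it.

Measured so far:
compound 1, `CCCCOc1ccc(-c2c(C)[nH]c(=O)n2C)cc1`: 5100 nM
compound 2, `CCCCc1ccc(-c2c(C)[nH]c(=O)n2CCCC)cc1`: 12000 nM

In a functional assay on brain (Rattus norvegicus, strain Wistar) for inhibition (a lower number here means a stronger inhibitor, a higher number a weaker inhibitor), compound 1 gives 5100 nM, the lower of the two numbers in hand. Compound 2 gives 12000 nM, a gap beyond the scatter. Among the compounds with values here, compound 2 differs from compound 1 in more than one place, so no single step between them is known; only the two values themselves stand for comparison.

Compound 3 is `CCCCCCc1ccc(-c2c(C)[nH]c(=O)n2C)cc1`. It differs from compound 1 in one place: hexyl in place of butoxy on an aromatic carbon. Within the data shown here, no measured pair shows this change, so its size is open. Among the measured compounds shown here, compound 2, the only other compound measured, gives 12000 nM, so a step toward a weaker inhibitor is expected for compound 3, of modest size, plausibly within the scatter or just beyond it. For compound 3 a value of 7500 nM is expected in this assay, within 2500 nM to 22000 nM, a step of a 1.5-fold higher number from compound 1 to compound 3 (0.17 log units; within the scatter).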

Compound 3, half-maximal inhibitory concentration: 9000 nM
Beside the measured number, compound 3's estimate is 1.2-fold (0.08 log units) below it, within the range that was stated.
By their numbers in this assay, from the lowest: compounds 1, 3 and 2 (each within the scatter of the next, the first and the last beyond it).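

In this assay, hexyl in place of butoxy on the aromatic carbon gives a 1.8-fold higher number from compound 1 to compound 3 (0.25 log units; within the scatter), so this exchange cannot be told apart from repeated-measurement noise. Removing the oxygen of the butoxy group and lengthening the chain to hexyl therefore leaves no measurable mark at this position, which the earlier pair could not show because compound 1 and compound 2 differ in more than one place. Nothing measured here explains this outcome or links it to any property of either group.

From the compounds shown here alone, whether a group of another kind at this position, such as an amine or a carboxylic acid, would move the number beyond the scatter remains open. Also open, going by these compounds, is what a single exchange of the methyl group on the shared core for a longer chain would do.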